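The source may hold more compounds than are shown below. What is called first, only, known or untested is meant among the compounds shown, and "the series" means these compounds.

Compounds measured in an assay on COS-7 cells for inhibition of patatin-like phospholipase domain-containing protein 2 (Mus musculus), tested at 200 uM; a lower number here means less inhibition, a higher number more inhibition at the concentration tested (going by the name of the read-out):
Compound 1, `CCNS(=O)(=O)c1cccc(-c2ccc(OCC)cc2)c1`: compound 1 gives 46%
Compound 2, `CCCCOC(=O)c1cccc(-c2ccc(OCC)cc2)c1`: compound 2 gives 61%
Compound 3, `CCOc1ccc(-c2cccc(C(=O)NC)c2)cc1`: compound 3 gives 40%

Compound 3 stands lowest of the three numbers in this assay. Its nearest neighbour is compound 1, a step of a number 6 percentage points lower from compound 1 to compound 3 (within the scatter); its furthest is compound 2, a step of a number 21 percentage points lower from compound 2 to compound 3 (beyond the scatter).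

Compound 4, `CCOc1ccc(-c2cccc(NC(C)=O)c2)cc1`, has not yet been measured in this assay. It differs from compound 3 in one place: acetamido in place of methylcarbamoyl on an aromatic carbon. The two compounds share the same atoms joined differently.

Within the data shown here, two measured steps touch the same position of the shared core. The exchange of ethylsulfamoyl for methylcarbamoyl, a number 6 percentage points lower from compound 1 to compound 3 (within the scatter), lay within the scatter; the exchange of butoxy for methylamino on the carbonyl carbon, a number 21 percentage points lower from compound 2 to compound 3 (beyond the scatter), was modest. Among the measured compounds shown here, no measured step reverses the amide itself, so the expectation rests on the small spread seen among compounds 1 and 3. For compound 4 the step from compound 3 is estimated at a number 2 percentage points higher from compound 3 to compound 4 (within the scatter), within the scatter. Compound 4 is therefore expected to give 42% in this assay, in a range from 22% to 62%.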

Compound 4, a percentage reported as inhibition, at one concentration (the size of the read-out at that concentration, not a potency): 52%
For compound 4 the middle estimate is 10 percentage points below the measured one, and the stated range covers the measured number.
By their numbers in this assay, from the lowest: compounds 3, 1, 4 and 2 (each within the scatter of the next, the first and the last beyond it).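

In this assay, the direction of the amide at this position matters: with the same atoms and the same counted donor and acceptor, the change gives a number 12 percentage points higher from compound 3 to compound 4 (beyond the scatter). The acetamido group cannot be separated from either of the other two groups at this position, with a number 9 percentage points lower from compound 2 to compound 4 (within the scatter) and a number 6 percentage points higher from compound 1 to compound 4 (within the scatter), although butoxycarbonyl and ethylsulfamoyl themselves differ beyond the scatter. Nothing available explains why joining the same atoms differently shifts the read-out.

As far as these compounds go, it remains open whether this shift would persist with a longer chain on the acetamido carbonyl, or how a plain amine or a carboxylic acid on this aromatic carbon would compare. With one concentration per compound, these numbers also leave the potency of all four compounds undefined.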